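A few compounds are considered here, and "the series" means these few. Any claim that something is new, unique, unknown or untested is made for them only; others in the source may bear on it.

Series notes. Compound 1 `COc1ccc2occ(C(=O)NC3CCN(Cc4ccccc4)CC3)c(=O)c2c1` carries a methoxy on the core; in an assay on isolated protein for inhibition of Amine oxidase [flavin-containing] B (Homo sapiens), read by fluorescence and Amplex Red, with stated times of 15 min and 20 min (on this read-out lower numbers stand for stronger inhibition and higher numbers for weaker inhibition), compound 1 gives 46300 nM. Compound 2 `O=C(NC1CCN(Cc2ccccc2)CC1)c1coc2ccc(Br)cc2c1=O` differs from it by bromo in place of methoxy on an aromatic carbon and in this assay compound 2 gives 22800 nM, so that the step is a 2.0-fold lower number from compound 1 to compound 2 (0.31 log units; beyond the scatter). Compound 3 `COc1ccc2c(=O)c(C(=O)NCCC3CCN(Cc4ccccc4)CC3)coc2c1` has a different core from compound 1; the difference between the two cores is not broken down here. In this assay compound 3 gives 30900 nM, within the scatter of compound 2 and of compound 1. Compound 4 `O=C(NCCC1CCN(Cc2ccccc2)CC1)c1coc2cc(Br)ccc2c1=O` is not yet measured and differs from compound 3 by bromo in place of methoxy on an aromatic carbon, the same change, at the same place, as that from compound 1 to compound 2. For the measured compounds named here, the step from compound 3 to compound 4 is estimated as a 1.9-fold lower number from compound 3 to compound 4 (0.29 log units; within the scatter), resting only on the one earlier step of a 2.0-fold lower number from compound 1 to compound 2 (0.31 log units; beyond the scatter). On that basis compound 4 is expected at 16000 nM, with 7000 nM to 35000 nM as the expected range.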

Compound 4, half-maximal inhibitory concentration: 29500 nM
Compound 4: the middle estimate sits 1.8-fold (0.27 log units) below what was measured; low and high end bracket the measured number.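

In this assay, bromo in place of methoxy on an aromatic carbon gives a 1.0-fold lower number from compound 3 to compound 4 (0.02 log units; within the scatter), which stays within the scatter, while the earlier step was a 2.0-fold lower number from compound 1 to compound 2 (0.31 log units; beyond the scatter). Set side by side, the two steps do not separate: the same change on two cores in this assay, a 2.0-fold lower number (0.31 log units; beyond the scatter) from compound 1 to compound 2 and a 1.0-fold lower number (0.02 log units; within the scatter) from compound 3 to compound 4, 1.9-fold (0.29 log units) apart, within the scatter of two such steps

For the compounds shown here, this shows no difference in the effect of the change on the two cores, but with only two pairs it does not show that the step carries over at a fixed size, nor that it depends on the core. Open, from the compounds shown here alone, is whether another group on this aromatic carbon, such as chloro, hydroxyl or an amine, would give a step beyond the scatter on both cores. Also open, going by these compounds, is how a longer chain in the amide side arm would behave.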